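From 4-pentylphenyl to tert-butyl: an antiproliferative step

The compounds below may be only part of what the source reports. "The series", "measured", "known", "first", "only" and "open" are said of these compounds alone.

Three related compounds have been tested in a functional assay on HCT-116 cells (Homo sapiens) for antiproliferative activity, read by MTT assay, with a stated time of 72 h; a lower number here means a stronger inhibitor, a higher number a weaker inhibitor. Compound 1 `O=C1O[C@H]([C@@H](O)Cn2cc(-c3cc(C(F)(F)F)cc(C(F)(F)F)c3)nn2)C(OCc2ccccc2)=C1OCc1ccccc1` gives 57200 nM, and compound 2 `CCCCCc1ccc(-c2cn(C[C@H](O)[C@H]3OC(=O)C(OCc4ccccc4)=C3OCc3ccccc3)nn2)cc1` gives 13800 nM. Compound 2 holds the lower of these two numbers, and its gap to compound 1 lies beyond the scatter. Compound 3 `COc1ccc(-c2cn(C/C=C3\OC(=O)C(OCc4ccccc4)=C3OCc3ccccc3)nn2)cc1` returns only a limit, > 100000 nM.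

The next compound is compound 4 `CC(C)(C)c1cn(C[C@H](O)[C@H]2OC(=O)C(OCc3ccccc3)=C2OCc2ccccc2)nn1`, which has not yet been measured. It keeps the core of compound 2 and changes one group: tert-butyl in place of 4-pentylphenyl on an aromatic carbon. The new tert-butyl sits on an aromatic carbon of a five-membered aromatic ring with 3 nitrogen, where 4-pentylphenyl stood. Among the measured compounds shown here, no measured pair here isolates a single change, so the size of this step has no direct precedent. For the measured compounds named here, compound 2 at 13800 nM is the only measured compound with 4-pentylphenyl, and compound 1, which lacks that group, stands at 57200 nM. On that thin basis, a weaker result beyond the scatter is expected in this assay, with an expected step of a 4.0-fold higher number from compound 2 to compound 4 (0.60 log units; beyond the scatter). For compound 4 the estimated value is 55000 nM, with an expected range from 22000 nM to 100000 nM. A reading that reports only a limit remains a real possibility.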

Compound 4, half-maximal inhibitory concentration: 28300 nM
The estimate for compound 4 lay 1.9-fold (0.29 log units) above the measured number; low and high end bracket the measured number.
By their numbers in this assay, from the lowest: compound 2; then compound 4; then compound 1. At a limit, above all of these: compound 3.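

Among the compounds shown here, this is the first step here that isolates a single change. In this assay tert-butyl in place of 4-pentylphenyl gives a 2.1-fold higher number from compound 2 to compound 4 (0.31 log units; beyond the scatter) and so puts a modest size on the exchange at this aromatic carbon of the five-membered aromatic ring with 3 nitrogen. The six-membered aromatic ring and the pentyl chain are thus not needed for a measured antiproliferative reading: compound 4, with tert-butyl and no ring in that group, still gives a number and not a limit. Compound 3 remains the only compound reported as a limit: the limit of > 100000 nM in this assay, at which 1 of the 4 values shown sits.

The compounds shown leave open which part of 4-pentylphenyl carries the difference; a plain phenyl or a pentyl chain on the same carbon would separate the ring from the chain. They also do not say how an amine or a carboxylic acid at this position would compare with tert-butyl or 4-pentylphenyl, and no measured cause for the step is available here.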